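A few compounds are considered here, and "the series" means these few. Any claim that something is new, unique, unknown or untested is made for them only; others in the source may bear on it.

Of the compounds shown here, three on a shared core have been tested in a functional assay on RAW264.7 cells (Mus musculus) for inhibition, read by Griess assay, with stated times of 2 h and 12 h; on this read-out lower numbers stand for stronger inhibition and higher numbers for weaker inhibition. Compound 1 `CCC/C=C\C=C\CCc1cc(O)c([C@@H]2O[C@H](CO)[C@@H](O)[C@H](O)[C@H]2O)c(O)c1C(=O)OC` carries one extra group on the core, and in this assay compound 1 gives 14000 nM. Compound 2 `CCC/C=C/C=C/CCc1cc(O)c([C@@H]2O[C@H](CO)[C@@H](O)[C@H](O)[C@H]2O)c(O)c1` lacks that group. In this assay compound 2 reaches only a limit of the assay, > 40000 nM. Compound 3 `CCC/C=C/C=C\CCc1cc(O)c([C@@H]2O[C@H](CO)[C@@H](O)[C@H](O)[C@H]2O)c(O)c1` has the same atoms and bonds as compound 2 and differs only in the drawn configuration of one double bond in the chain. In this assay compound 3 likewise stops at a limit of the assay, > 40000 nM. The step that the two limits leave unreadable from compound 2 to compound 3 cannot be read, because the limit of > 40000 nM in this assay, at which 2 of the 3 values shown sit, leaves both ends without a number. Compound 3 therefore stands with no value of its own, sharing its limit with one other compound.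

Compound 4 `CCC/C=C\C=C\CCc1cc(O)c([C@@H]2O[C@H](CO)[C@@H](O)[C@H](O)[C@H]2O)c(O)c1` is the next step: the two compounds have the same atoms and bonds and differ only in configuration as drawn: 2 of 7 stereo elements differ; a double bond is drawn E in compound 3 and Z in compound 4; a double bond is drawn Z in compound 3 and E in compound 4. Going by the values given here, the only measured precedent for a change of this kind is the pair of compounds 2 and 3, whose difference is the fact that compounds 2 and 3 differ only in the configuration as drawn, and that pair gives no readable size. With no measured guide, compound 4 is expected to stay close to where compound 3 sits, an estimated step of a number no higher from compound 3 to compound 4 (the limit leaves the size open). For compound 4 the estimate in this assay is 40000 nM, with a range from 15000 nM to 100000 nM, and a real chance that only a limit is reported again.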

Compound 4, half-maximal inhibitory concentration: 30000 nM
The estimate for compound 4 lay 1.3-fold (0.12 log units) above the measured number; the range from low to high includes it.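

Going by these compounds alone, compound 4 gives the first clean look at the methoxycarbonyl group: it carries the same drawn chain as compound 1 and differs from it in one place only, hydrogen in place of methoxycarbonyl on an aromatic carbon. In this assay that change is a 2.1-fold higher number from compound 1 to compound 4 (0.33 log units; beyond the scatter), so for this single pair the compound with hydrogen is modestly weaker than the one with methoxycarbonyl. The geometry steps an at least 1.3-fold lower number from compound 3 to compound 4 (0.12 log units; that floor lies within the scatter) and an at least 1.3-fold lower number from compound 2 to compound 4 (0.12 log units; that floor lies within the scatter) are only floors within the scatter, and the step between the two compounds held at a limit cannot be read, so no order among the chain geometries can be claimed, and geometry is all that separates these compounds: the fact that compounds 3 and 4 differ only in the configuration as drawn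

From the compounds shown here alone, it stays open whether a carboxylic acid or an amide in place of methoxycarbonyl would move the number further than this modest step. Equally open, going by these compounds, is how a longer chain, or a chain with both double bonds drawn Z, would read out in this assay.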